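The source may report more compounds than this note shows. Statements on the series, on what has been measured and on what is new or still open speak of the compounds shown alone.

Compound 3 `Cn1nnnc1SCC(=O)Nc1ccc(-c2nc(-c3ccccc3)c(-c3ccccc3)n2C)cc1` stands highest of the three numbers measured in a functional assay on MCF7 cells (Homo sapiens) for cytotoxicity, read by MTT assay, with a stated time of 24 h, tested at 0.64 ug/mL (on this read-out higher numbers stand for a stronger effect at the one concentration tested and lower numbers for a weaker effect), where compound 3 gives 21.9%. Compound 1 `Cn1c(-c2ccc(NC(=O)CSc3nc4cc(Cl)ccc4o3)cc2)nc(-c2ccccc2)c1-c1ccccc1` gives 2.4% in this assay, and compound 2 `Cc1ccc2oc(SCC(=O)Nc3ccc(-c4nc(-c5ccccc5)c(-c5ccccc5)n4C)cc3)nc2c1` gives 1.1%. The two steps that reach compound 3 are both beyond the scatter: a number 19.5 percentage points higher from compound 1 to compound 3 (beyond the scatter) and a number 20.8 percentage points higher from compound 2 to compound 3 (beyond the scatter), whereas the step between the two lower compounds, a number 1.3 percentage points lower from compound 1 to compound 2 (within the scatter), is within it.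

Compound 4 `CN1CCN(CC(=O)Nc2ccc(-c3nc(-c4ccccc4)c(-c4ccccc4)n3C)cc2)CC1` differs from compound 3 in one place: 4-methylpiperazin-1-yl in place of (1-methyl-1H-tetrazol-5-yl)sulfanyl on a saturated chain carbon bound to a carbonyl carbon. Among the measured compounds shown here, no measured step exchanges the group on the sulfur for a group without sulfur, so none bears directly on this change; the measured steps show only that altering the group carried by the sulfur moved the number modestly, while a change on the more distant ring did not. With compound 3 standing alone above the other two, the expectation for compound 4 is a modest step downward, a number 9.9 percentage points lower from compound 3 to compound 4 (within the scatter), wide in its uncertainty. Compound 4 is therefore estimated at 12%, with a range from 1% to 35%.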

Compound 4, a percentage reported as activity, at one concentration (the size of the read-out at that concentration, not a potency): 1.1%
Beside the measured number, compound 4's estimate is 10.9 percentage points above it; low and high end bracket the measured number.
By their numbers in this assay, from the lowest: compounds 2, 4 and 1 (each within the scatter of the next); then compound 3.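

In this assay, among the compounds shown here, replacing (1-methyl-1H-tetrazol-5-yl)sulfanyl with 4-methylpiperazin-1-yl on a saturated chain carbon bound to a carbonyl carbon gives a number 20.8 percentage points lower from compound 3 to compound 4 (beyond the scatter), the only step here to a group without sulfur that lies beyond the scatter. The same replacement gives no change at the digits printed from compound 2 to compound 4 (within the scatter) and a number 1.3 percentage points lower from compound 1 to compound 4 (within the scatter), so among these four compounds the higher number belongs to the (1-methyl-1H-tetrazol-5-yl)sulfanyl group alone, and sulfur at this place does not bring it, as compound 1 and compound 2 also carry sulfur. Nothing available explains this difference.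

The compounds shown leave open whether the higher number needs the sulfur link or the 1-methyl-1H-tetrazol-5-yl ring itself. They also do not say how a morpholin-4-yl group, a carboxylic acid or a longer chain at this place would read.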